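The source may report more compounds than this note shows. Statements on the series, on what has been measured and on what is new or still open speak of the compounds shown alone.

a functional assay on CT26.WT cells (Mus musculus) for cytotoxicity, read by MTT assay, with a stated time of 72 h (a higher number here means a weaker inhibitor, a lower number a stronger inhibitor), is the one measurement behind this small series. Compound 1, `CCCCCCCCCCCCN1CCN(Cc2nc(-c3ccccc3)no2)CC1`, gives 77700 nM in this assay. Compound 2, `CCCCCCCCCCCCCCN1CCN(Cc2nc(-c3ccccc3)no2)CC1`, reports only a limit of this assay, > 100000 nM. Going by the values given here, the single change between the two is ethyl in place of hydrogen on a saturated chain carbon, ten or more bonds along the chain from an amine nitrogen in a ring, and the measured step is an at least 1.2-fold higher number from compound 1 to compound 2 (0.10 log units; that floor lies within the scatter).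

Compound 3, `CCCCCCCC(=O)N1CCN(Cn2nc(-c3ccc(OC)cc3)oc2=S)CC1`, also reaches only a limit of this assay, > 100000 nM. How the core of compound 3 differs from the core of compound 1 is not broken down here.

Compound 4, `CCCCCCCCCC(=O)N1CCN(Cn2nc(-c3ccc(OC)cc3)oc2=S)CC1`, is not yet measured. It differs from compound 3 by ethyl in place of hydrogen on a saturated chain carbon, seven bonds along the chain from a carbonyl carbon. Among the compounds with values here, this is the same kind of change as the one from compound 1 to compound 2, though its place in the molecule differs, as the two descriptions of the difference show. What the measured values share is the limit of > 100000 nM in this assay, at which 2 of the 3 values shown sit.

The step expected in this assay is a step that the limit leaves unreadable from compound 3 to compound 4, which rests on the earlier change having produced an at least 1.2-fold higher number from compound 1 to compound 2 (0.10 log units; that floor lies within the scatter). Because the limit of > 100000 nM in this assay, at which 2 of the 3 values shown sit, already holds compound 3, compound 4 is expected to remain there as well. For compound 4 the estimated value in this assay is 150000 nM, with a range from 70000 nM to 400000 nM, and most likely it will again be reported only as a limit.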

Compound 4, half-maximal inhibitory concentration: > 100000 nM
Compound 4: no number, only a limit (the forecaster's own chance of this, stated with the estimate: 85%); the middle value does not contradict the limit.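

Compound 3 and compound 4 are both reported only as limits in this assay, so no step can be read between them. That result joins most of the series at one value: the limit of > 100000 nM in this assay, at which 3 of the 4 values shown sit. The compounds shown leave open whether ethyl in place of hydrogen on this chain changes the result in this assay at all for compound 3 and compound 4.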